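The source may report more compounds than this note shows. Statements on the series, on what has been measured and on what is new or still open speak of the compounds shown alone.

Measured so far:
- compound 1, `NC(=O)c1c(NC(=O)c2ccccc2Cl)sc2c1CCN(C(=S)Nc1ccccc1C(F)(F)F)C2`: 10600 nM
- compound 2, `NC(=O)c1c(NC(=O)c2ccccc2)sc2c1CCN(C(=S)Nc1ccccc1Cl)C2`: 13800 nM
- compound 3, `NC(=O)c1c(NC(=O)c2ccccc2F)sc2c1CCN(C(=O)Nc1ccccc1Cl)C2`: 32700 nM

All three share one core and were tested in a functional assay on HL-60 cells (Homo sapiens) for antiproliferative activity, with a stated time of 24 h; a higher number here means a weaker inhibitor, a lower number a stronger inhibitor. Compound 2 gives 13800 nM there, the second highest of the three numbers. Its nearest neighbour is compound 1 at 10600 nM, a gap that lies within the scatter of repeated measurements, so the two cannot be told apart. Compound 3, at 32700 nM, sits further away, with a number beyond the scatter and higher than that of compound 2.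

Compound 4, `NC(=O)c1c(NC(=O)c2ccccc2C(F)(F)F)sc2c1CCN(C(=S)Nc1ccccc1Cl)C2`, has not yet been tested in this assay. It differs from compound 2 in one place: trifluoromethyl in place of hydrogen on an aromatic carbon, so the plain phenyl on the amide side becomes 2-(trifluoromethyl)phenyl, and the new group sits on an aromatic carbon of a six-membered aromatic ring of carbon only, ortho to a large group. Among the compounds with values here, no measured pair in this set shows this exact change, so the size of the step cannot be taken from data. The expectation is a step from compound 2 to compound 4 of a 1.2-fold lower number from compound 2 to compound 4 (0.06 log units; within the scatter), in no firm direction and not beyond the scatter. Compound 4 is therefore estimated at 12000 nM in this assay, within a range from 5000 nM to 30000 nM.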

Compound 4, half-maximal inhibitory concentration: 17600 nM
Estimate against measurement, compound 4: 1.5-fold (0.17 log units) below, within the range that was stated.
By their numbers in this assay, from the lowest: compounds 1, 2, 4 and 3 (each within the scatter of the next, the first and the last beyond it).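

In this assay, replacing a hydrogen of the plain phenyl on the amide side with trifluoromethyl, which gives 2-(trifluoromethyl)phenyl, produces a 1.3-fold higher number from compound 2 to compound 4 (0.11 log units; within the scatter), a step that cannot be told apart from the scatter of repeated measurements. Within the data shown here, this is the first pair in the set that differs in only one place, so it is the first direct reading of this position, which the earlier compounds could not isolate because they differed from one another in more than one place. At this position and on this background, four heavy atoms can therefore take the place of a hydrogen with no measurable change in the number, although nothing available explains why the step is so small.

From the compounds shown here alone, what a group of another kind would do at this position stays open: an amine or a carboxylic acid, or simply a methyl, might or might not move the number beyond the scatter. Also open, going by these compounds, is whether the same change would give a similar step in a compound carrying the carbonyl of compound 3 in place of the thiocarbonyl of compound 4.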